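Swapping the Benzyl Substituent and Shortening the Chain

The compounds below may be only part of what the source reports. "The series", "measured", "known", "first", "only" and "open" are said of these compounds alone.

Two sulfonamides built on one shared core have so far been measured in a functional assay on BE(2)-C cells (Homo sapiens) for inhibition, read by MTT assay, with a stated time of 72 h; a lower number here means a stronger inhibitor of growth, a higher number a weaker inhibitor of growth. Compound 1 `O=S(=O)(NCCCCNCc1ccc(Br)cc1)c1cc(C(F)(F)F)cc(C(F)(F)F)c1` gives 2200 nM in this assay, the lower of the two numbers recorded. Compound 2 `CC(C)(C)c1ccc(CNCCNS(=O)(=O)c2cc(C(F)(F)F)cc(C(F)(F)F)c2)cc1` gives 14000 nM in this assay, a weaker inhibitor of growth, and the gap between the two lies beyond the usual scatter of such measurements. Compound 3 `COc1cccc(CNCCCNS(=O)(=O)c2cc(C(F)(F)F)cc(C(F)(F)F)c2)c1` has not yet been measured in this assay. It differs from compound 1 by (3-methoxybenzyl)amino in place of ((4-bromobenzyl)amino)methyl on a saturated chain carbon, three bonds along the chain from a sulfonamide nitrogen. Because compound 2 gives 14000 nM in this assay, the step of a 2.0-fold higher number from compound 1 to compound 3 (0.31 log units; beyond the scatter) is expected to be a modest move toward weaker inhibition of growth, although the direction remains uncertain. Compound 3 is therefore estimated at 4500 nM in this assay, with a range from 1500 nM to 14000 nM.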

Compound 3, concentration for 50% growth inhibition: 4500 nM
Compound 3: the middle estimate sits on the measured number at the digits printed; measured number inside the range.
By their numbers in this assay, from the lowest: compound 1; then compound 3; then compound 2.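

In this assay, putting (3-methoxybenzyl)amino in place of ((4-bromobenzyl)amino)methyl on a saturated chain carbon, three bonds along the chain from a sulfonamide nitrogen, gives a 2.0-fold higher number from compound 1 to compound 3 (0.31 log units; beyond the scatter) and so provides the first step read between compounds differing in one place. The leaving and entering groups both have 10 heavy atoms and one six-membered aromatic ring of carbon only, while the hydrogen-bond acceptors go from 1 to 2, and the shift in growth inhibition remains modest. No measurement accompanies this step to account for the shift. The step changes the benzyl substituent and the chain together, leaving the contribution of each unresolved. A 3-methoxybenzyl group on the longer chain of compound 1, or a 4-bromobenzyl group on the chain of compound 3, would separate the two.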